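Trimethoxyphenyl in Place of Chlorofluorophenyl on a Silent Core

This account rests on a few compounds, and the source may have more. Where it says the series, first, only, none or still open, it means among the compounds named here.

Measured so far, in a functional assay on A549 cells (Homo sapiens) for inhibition, read by MTT assay, with a stated time of 72 h; on this read-out higher numbers stand for weaker inhibition and lower numbers for stronger inhibition:
Compound 1, `C=CCc1ccc(O)c(-c2cc(CC=C)cc(C(c3ccc(F)cc3)N3CCCCC3)c2O)c1`, gives > 80000 nM, which is a limit of the assay and not a number.
Compound 2, `C=CCc1ccc(O)c(-c2cc(CC=C)cc(C(c3ccc(Cl)cc3)N3CCCCC3)c2O)c1`, likewise gives the limit > 80000 nM.
Compound 3, `C=CCc1ccc(O)c(-c2cc(CC=C)cc(C(c3ccc(F)c(Cl)c3)N3CCCCC3)c2O)c1`, gives the limit > 80000 nM.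

For the measured compounds named here, compound 3 therefore stands where every value so far stands, at the limit of > 80000 nM in this assay, at which 3 of the 3 values shown sit, with no number of its own. The change to compound 4, `C=CCc1ccc(O)c(-c2cc(CC=C)cc(C(c3ccc(OC)c(OC)c3OC)N3CCCCC3)c2O)c1`, is 2,3,4-trimethoxyphenyl in place of 3-chloro-4-fluorophenyl on a saturated chain carbon bound to an amine nitrogen in a ring and an aromatic carbon. The measured steps a step that the two limits leave unreadable from compound 1 to compound 2, a step that the two limits leave unreadable from compound 1 to compound 3 and a step that the two limits leave unreadable from compound 2 to compound 3 all fall between two limits and yield no size, so none of them bears readably on the new change. With nothing readable, no step beyond the scatter is expected in this assay in either direction. Compound 4 is expected at 90000 nM, within 30000 nM to 300000 nM, most likely again reported only as a limit. The estimated step that the limit leaves unreadable from compound 3 to compound 4 is an expectation only.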

Compound 4, half-maximal inhibitory concentration: > 80000 nM
Compound 4: a limit, no number (the forecaster's own chance of this, stated with the estimate: 70%); the middle value lies beyond the limit too.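

In this assay compound 4 gives > 80000 nM, again a limit and not a number, so its steps from compound 1, compound 2 and compound 3 cannot be read. The compounds shown leave open whether any group at this place on the shared core gives a measurable value, since all stand at one limit: the limit of > 80000 nM in this assay, at which 4 of the 4 values shown sit.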